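Trading methoxy for methyl on the aryl ring

The source may hold more compounds than are shown below. What is called first, only, known or untested is meant among the compounds shown, and "the series" means these compounds.

Of the compounds shown here, three sharing one core have been measured in a physicochemical assay for lipophilicity, measured as octanol-water partition, at pH 7.4; a higher number here means a more lipophilic compound, a lower number a more polar compound. Compound 1 `CC(C)c1ccc(NC2=NCCC3(CCCCC3)S2)cc1` gives 1.57. Compound 2 `COc1ccc(NC2=NCCC3(CCCCC3)S2)cc1` gives 0.8, the lowest of the three numbers. Compound 3 `CCc1cccc(CC)c1NC1=NCCC2(CCCCC2)S1` gives 1.88, the highest of the three. The one step that joins two of these compounds in a single change, a number 0.77 log units lower from compound 1 to compound 2 (beyond the scatter), shows that exchanging the isopropyl group for methoxy lowers the reading by a modest amount that lies beyond the scatter.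

The next compound, compound 4 `Cc1ccc(NC2=NCCC3(CCCCC3)S2)cc1`, differs from compound 2 in one place: methyl in place of methoxy on an aromatic carbon. This is the reverse direction of the measured step in kind, since a group holding an oxygen leaves and a plain carbon group enters, though methyl is smaller than isopropyl. A rise is therefore expected in this assay, but one smaller than the step between compound 1 and compound 2, so that compound 4 should sit between compound 2 and compound 1. The expected step is a number 0.45 log units higher from compound 2 to compound 4 (beyond the scatter). Compound 4 is estimated at 1.25, with a range from 0.95 to 1.55.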

Compound 4, distribution coefficient: 1.56
Compound 4: middle estimate off by 0.31 log units, on the low side; the measured number lies above the stated range.
By their numbers in this assay, from the lowest: compound 2; then compounds 4 and 1 (each within the scatter of the next); then compound 3.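

At this position, para to a large group, putting methyl in place of methoxy gives a number 0.76 log units higher from compound 2 to compound 4 (beyond the scatter), a rise about as large as the fall seen for a number 0.77 log units lower from compound 1 to compound 2 (beyond the scatter) in this assay. The earlier compounds could not show that the size of the carbon group matters little here, but the step of a number 0.01 log units lower from compound 1 to compound 4 (within the scatter) leaves methyl and isopropyl indistinguishable, so among these three compounds, only the methoxy compound, compound 2, stands apart. No measurement available here explains why.

On these data alone, it remains open whether a longer chain, an amine or a hydroxyl group at this position would read like the two carbon groups or like methoxy. As far as these compounds go, whether the same exchange gives a similar step elsewhere on the aromatic ring also remains open.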